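Trifluoroacetyl thiophene oxadiazoles: aryl swap at the oxadiazole

The compounds below may be only part of what the source reports. "The series", "measured", "known", "first", "only" and "open" are said of these compounds alone.

Measured so far in an assay on isolated protein for inhibition of protein deacetylase HDAC6 (Homo sapiens); a higher number here means a weaker inhibitor, a lower number a stronger inhibitor:
compound 1 `O=C(c1ccc(-c2nc(-c3ccc(Cl)cc3Cl)no2)s1)C(F)(F)F` gives 3000 nM
compound 2 `O=C(c1ccc(-c2nc(-c3cccs3)no2)s1)C(F)(F)F` gives 670 nM

Compound 2 stands lowest of the two numbers in this assay; its nearest neighbour is compound 1, and the step of a 4.5-fold lower number from compound 1 to compound 2 (0.65 log units; beyond the scatter) separates them. Compound 3 `Cc1cccc(-c2noc(-c3ccc(C(=O)C(F)(F)F)s3)n2)c1` differs from compound 2 by 3-methylphenyl in place of thiophen-2-yl on an aromatic carbon. For the measured compounds named here, the only measured step that bears on this change is a 4.5-fold lower number from compound 1 to compound 2 (0.65 log units; beyond the scatter), where a six-membered carbon-only ring was replaced by the five-membered ring; compound 3 goes back to a six-membered carbon-only ring, though with a methyl group rather than two chlorines. A step in the opposite direction to that of compound 1 to compound 2 is therefore expected, but smaller, and it may not clear the scatter. For compound 3 the estimate in this assay is 1200 nM, between 400 nM and 4000 nM, a step of a 1.8-fold higher number from compound 2 to compound 3 (0.25 log units; within the scatter).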

Compound 3, half-maximal inhibitory concentration: 680 nM
Compound 3: the middle estimate sits 1.8-fold (0.25 log units) above what was measured; measured number inside the range.
By their numbers in this assay, from the lowest: compounds 2 and 3 (each within the scatter of the next); then compound 1.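

In this assay, 3-methylphenyl in place of thiophen-2-yl on this aromatic carbon gives a 1.0-fold higher number from compound 2 to compound 3 (0.01 log units; within the scatter), so a six-membered aromatic ring of carbon only can stand here with no step beyond the scatter from the five-membered ring. The step from 2,4-dichlorophenyl to 3-methylphenyl, a 4.4-fold lower number from compound 1 to compound 3 (0.64 log units; beyond the scatter), occurs between two six-membered carbon-only rings, which means ring size alone does not account for the higher number of compound 1. No measurement on hand explains this difference.

Going by these compounds, whether that higher number follows the two chlorines or where they sit stays open, as 3-methylphenyl changes both at once; a phenyl ring with a single chlorine would begin to separate them. Also open, on these data alone, is how a ring carrying an amine or a carboxylic acid behaves at this position.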